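The source may report more compounds than this note shows. Statements on the series, on what has been measured and on what is new or still open speak of the compounds shown alone.

Among the measured compounds shown here, compound 1 `COc1ccc(/C=C/c2nc(NCCN(C(C)C)C(C)C)c3cc(Cl)ccc3n2)cc1OC` is one of three compounds measured in a functional assay on T-24 cells (Homo sapiens) for cytotoxicity, read by MTT assay, with stated times of 48 h and 4 h (a lower number here means a stronger inhibitor, a higher number a weaker inhibitor), where compound 1 gives 14900 nM. Compound 2 `COc1ccc(/C=C/c2nc(NCCN3CCCCC3)c3cc(Cl)ccc3n2)cc1OC` carries the change piperidin-1-yl in place of diisopropylamino on a saturated chain carbon, two bonds along the chain from a nitrogen on an aromatic ring and in this assay compound 2 gives 7640 nM, a step of a 2.0-fold lower number from compound 1 to compound 2 (0.29 log units; within the scatter). Compound 3 `CC(C)N(CCNc1nc(/C=C/c2ccc([N+](=O)[O-])cc2)nc2ccccc12)C(C)C` rests on a different core; how the core of compound 3 differs from that of compound 1 is not broken down here. In this assay compound 3 gives 14200 nM, a number near that of compound 1 and within the usual scatter of it. Compound 4 `O=[N+]([O-])c1ccc(/C=C/c2nc(NCCN3CCCCC3)c3ccccc3n2)cc1` is not yet measured and differs from compound 3 by piperidin-1-yl in place of diisopropylamino on a saturated chain carbon, two bonds along the chain from a nitrogen on an aromatic ring, the same change seen from compound 1 to compound 2, at the same place. The step from compound 3 to compound 4 in this assay is expected to be about a 1.9-fold lower number from compound 3 to compound 4 (0.28 log units; within the scatter), resting on the measured step of a 2.0-fold lower number from compound 1 to compound 2 (0.29 log units; within the scatter), which did not rise above the scatter. Compound 4 is therefore estimated at 7500 nM, with a likely range from 3000 nM to 18000 nM.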

Compound 4, half-maximal inhibitory concentration: 36200 nM
For compound 4 the middle estimate is 4.8-fold (0.68 log units) below the measured one, and the stated range ends below it.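

In this assay, putting piperidin-1-yl in place of diisopropylamino gives a 2.5-fold higher number from compound 3 to compound 4 (0.41 log units; beyond the scatter), a modest loss on the core of compound 3. The same change therefore does not carry over with a constant size or direction between these two cores: the same change on two cores in this assay, a 2.0-fold lower number (0.29 log units; within the scatter) from compound 1 to compound 2 and a 2.5-fold higher number (0.41 log units; beyond the scatter) from compound 3 to compound 4, 5.0-fold (0.70 log units) apart, beyond the scatter of two such steps. This shows that the step measured on one core was not a safe guide to the step on the other, but it rests on just two pairs, and the earlier step lies within the scatter, so it establishes no real gain on the core of compound 1; nor does it show which of the several differences between the cores is responsible, or why the steps part.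

The compounds shown leave open whether the difference follows the chlorine, the methoxy groups or the nitro group, since these never vary alone here. They also leave open how other amines on the same chain, such as morpholin-4-yl or dimethylamino, or a longer chain such as 3-(piperidin-1-yl)propyl, would behave on either core.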